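A few compounds are considered here, and "the series" means these few. Any claim that something is new, unique, unknown or untested is made for them only; others in the source may bear on it.

Compound 1 `COc1cc2occ(-c3csc4ccccc34)c(=O)c2cc1OC` gives > 10000 nM as a limit of the assay
Compound 2 `O=C(/C=C/c1csc2ccccc12)c1cc(Br)ccc1O` gives 840 nM
Compound 3 `O=C(/C=C/c1csc2ccccc12)c1cc(Br)cc(Br)c1O` gives 4300 nM

In a functional assay on MDA-MB-231 cells (Homo sapiens) for antiproliferative activity, read by sulforhodamine B assay, with a stated time of 72 h (on this read-out lower numbers stand for stronger inhibition and higher numbers for weaker inhibition), compound 2 has the lower of the two actual numbers. Compound 4 `CC(C)Oc1ccc(O)c(C(=O)/C=C/c2csc3ccccc23)c1` has not yet been measured. It carries isopropoxy in place of bromo on an aromatic carbon, para to a hydroxy group isopropoxy in place of bromo on an aromatic carbon relative to compound 2. Within the data shown here, the one measured step that bears on this is a 5.1-fold higher number from compound 2 to compound 3 (0.71 log units; beyond the scatter) for bromo in place of hydrogen on an aromatic carbon, a modest step beyond the scatter. It does not test this exchange directly, so only a modest rise is expected in this assay on this evidence. The expected step is a 1.8-fold higher number from compound 2 to compound 4 (0.25 log units; within the scatter) in size. Compound 4 is estimated at 1500 nM with 400 nM to 6000 nM as the expected range.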

Compound 4, half-maximal inhibitory concentration: 8500 nM
For compound 4 the middle estimate is 5.7-fold (0.75 log units) below the measured one, outside the stated range (above it).
By their numbers in this assay, from the lowest: compound 2; then compounds 3 and 4 (each within the scatter of the next). At a limit, above all of these: compound 1.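

In this assay, the position para to a hydroxy group proves sensitive to what it carries: isopropoxy in place of bromo gives a 10-fold higher number from compound 2 to compound 4 (1.01 log units; beyond the scatter). Among these compounds, compounds 2 and 3 both carry bromo there, so this is the first exchange at this position itself. Compound 4 still gives a number rather than a limit, so this change does not reach the end of the assay's range: the limit of > 10000 nM in this assay, at which 1 of the 4 values shown sits.

On these data alone, whether methoxy, an amine or a carboxylic acid at this position would hold the number of compound 2 stays open. So does whether bromo is needed there at all, since no plain hydrogen at this position is shown.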